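Carbamate selenocyanates: ester chain grown from propyl to hexyl

A few compounds are considered here, and "the series" means these few. Any claim that something is new, unique, unknown or untested is made for them only; others in the source may bear on it.

Compound 1 `CCCOC(=O)Nc1ccc([Se]C#N)cc1` is the starting point of this step. In a functional assay on PC-3 cells (Homo sapiens) for cytotoxicity, read by MTT assay, with a stated time of 72 h (on this read-out lower numbers stand for stronger inhibition of growth and higher numbers for weaker inhibition of growth), compound 1 gives 47400 nM, the higher of the two numbers in hand. Among the measured compounds shown here, the only other measured member is compound 2 `Cc1ccc(OC(=O)Nc2ccc([Se][Se]c3ccc(NC(=O)Oc4ccc(C)cc4)cc3)cc2)cc1`, which differs from compound 1 in more than one place. In this assay compound 2 gives 28200 nM. For the measured compounds named here, the two values lie within the scatter of each other, so no order is read from them, and no single step between measured compounds can be drawn from this pair.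

Compound 3 `CCCCCCOC(=O)Nc1ccc([Se]C#N)cc1` is not yet measured. Relative to compound 1 the change is propyl in place of hydrogen on a saturated chain carbon, three bonds along the chain from an oxygen next to a carbonyl group, so the ester chain grows from propyl to hexyl while the selenocyanate arm and the shared core stay as they are. Going by the values given here, no measured pair here isolates a change of this kind, so the size of the step rests on judgement alone. A step of a 1.5-fold lower number from compound 1 to compound 3 (0.17 log units; within the scatter) is expected in this assay, a modest move toward a lower number that may still fall inside the scatter. For compound 3 the estimate in this assay is 32000 nM, with a range from 12000 nM to 85000 nM.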

Compound 3, concentration for total growth inhibition: 44600 nM
For compound 3 the middle estimate is 1.4-fold (0.14 log units) below the measured one, and the stated range covers the measured number.
By their numbers in this assay, from the lowest: compounds 2, 3 and 1 (each within the scatter of the next).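

In this assay, among the compounds shown here, the first step that can be read is a 1.1-fold lower number from compound 1 to compound 3 (0.03 log units; within the scatter), so propyl in place of hydrogen on this saturated chain carbon, three bonds along the chain from an oxygen next to a carbonyl group, leaves the read-out inside the scatter. With the selenocyanate arm and the shared core held as they are, the ester chain runs from propyl to hexyl without separating compound 1 from compound 3 on this read-out, which the earlier pair could not show, as compound 1 and compound 2 differ in more than one place. No measurement in hand bears on the reason for this result.

As far as these compounds go, whether a chain longer than hexyl, or a chain ending in an amine or a carboxylic acid, would separate from compound 1 at this place remains open. For the compounds shown here, also open is what the selenocyanate arm contributes on its own, since no pair here changes that arm while the ester group stays the same.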